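Fluoro for Chloro at a Second Position on the Anilino Ring

The source may report more compounds than this note shows. Statements on the series, on what has been measured and on what is new or still open speak of the compounds shown alone.

Four compounds share one core and differ only in the halogen pattern of the anilino ring. Compound 1 `C=CC(=O)Nc1cccc(NC(=O)CSc2nc(Nc3cccc(F)c3)c3ccccc3n2)c1` and compound 2 `C=CC(=O)Nc1cccc(NC(=O)CSc2nc(Nc3cccc(Cl)c3)c3ccccc3n2)c1` carry a single halogen. In a functional assay on MGC-803 cells (Homo sapiens) for inhibition, read by MTT assay, with a stated time of 72 h (on this read-out higher numbers stand for weaker inhibition and lower numbers for stronger inhibition), compound 1 gives 6250 nM and compound 2 gives 7830 nM; the change fluoro in place of chloro on an aromatic carbon produces a 1.3-fold lower number from compound 2 to compound 1 (0.10 log units; within the scatter). Compound 3 `C=CC(=O)Nc1cccc(NC(=O)CSc2nc(Nc3ccc(Cl)c(Cl)c3)c3ccccc3n2)c1` adds a second chloro. In this assay compound 3 reaches only the limit > 50000 nM, a limit of the measurement and not a number. Against compound 1 that is an at least 8.0-fold higher number from compound 1 to compound 3 (0.90 log units; beyond the scatter), and against compound 2, through (chloro in place of hydrogen on an aromatic carbon), it is an at least 6.3-fold higher number from compound 2 to compound 3 (0.80 log units; beyond the scatter).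

Compound 4 `C=CC(=O)Nc1cccc(NC(=O)CSc2nc(Nc3ccc(F)c(Cl)c3)c3ccccc3n2)c1` is not yet measured. It differs from compound 3 by fluoro in place of chloro on an aromatic carbon. This is the same kind of change as that from compound 2 to compound 1, yet not the same: there the place was meta to a large group, here it is ortho to a chloro group and para to a large group. The two cores differ by the chloro group named above.

The account expects a small step, since the earlier swap in compound 2 gave only a 1.3-fold lower number from compound 2 to compound 1 (0.10 log units; within the scatter), and since compound 3 sits at the limit (the limit of > 50000 nM in this assay, at which 1 of the 3 values shown sits). Compound 4 is therefore estimated at 45000 nM, with a range from 15000 nM to 150000 nM. From compound 3 this would mean an expected at least 1.1-fold lower number from compound 3 to compound 4 (0.04 log units; that floor lies within the scatter).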

Compound 4, half-maximal inhibitory concentration: 7850 nM
Compound 4: the middle estimate sits 5.7-fold (0.76 log units) above what was measured, outside the stated range (below it).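

In this assay the change of fluoro in place of chloro does not carry over from one core to the other with the same size: the same change on two cores in this assay, a 1.3-fold lower number (0.10 log units; within the scatter) from compound 2 to compound 1 and an at least 6.3-fold lower number (0.80 log units; beyond the scatter) from compound 3 to compound 4, at least 5.0-fold (0.70 log units) apart, beyond the scatter of two such steps

On the core that already holds a second chloro group the change gives an at least 6.3-fold lower number from compound 3 to compound 4 (0.80 log units; beyond the scatter), while fluoro in place of hydrogen gives a 1.0-fold higher number from compound 2 to compound 4 (0.00 log units; within the scatter), and the wider change from the 3-fluorophenyl group gives a 1.3-fold higher number from compound 1 to compound 4 (0.10 log units; within the scatter), so compound 4 stands level with both single-halogen compounds. Compound 3 sits at a limit of the assay and not at a number, so its step and the gap between the two steps are floors only, and a single pair on each core shows neither why the change differs nor how it would behave on any further core: the limit of > 50000 nM in this assay, at which 1 of the 4 values shown sits.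

The compounds shown leave open whether a group other than a halogen at the place para to a large group, such as methyl, methoxy or an amine, would fall with compound 3 or with compound 4. They also leave open whether a ring carrying two fluoro groups, or bromo in place of the fluoro of compound 4, would follow the same course.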